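Aryl variation and cytotoxicity across the shared core

This account rests on a few compounds, and the source may have more. Where it says the series, first, only, none or still open, it means among the compounds named here.

Measured compounds:
compound 1 `N#Cc1c(-c2cccc(F)c2)c(C#N)c(=O)n(/N=C/c2cn(-c3ccccc3)nc2-c2ccccc2)c1N`, 154 ug/mL
compound 2 `COc1ccc(-c2c(C#N)c(N)n(/N=C/c3cn(-c4ccccc4)nc3-c3ccccc3)c(=O)c2C#N)cc1`, 50 ug/mL

For the measured compounds named here, in an ADME assay on NIH3T3 cells (Mus musculus) for cytotoxicity, read by MTT assay (a higher number here means a weaker inhibitor, a lower number a stronger inhibitor), compound 2 gives 50 ug/mL, the lowest of the two numbers so far; the nearest is compound 1, which gives 154 ug/mL. Going by the values given here, the one measured step, a 3.1-fold lower number from compound 1 to compound 2 (0.49 log units; beyond the scatter), goes with the change from 3-fluorophenyl to 4-methoxyphenyl on the core.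

Compound 3 `N#Cc1c(-c2cccc([N+](=O)[O-])c2)c(C#N)c(=O)n(/N=C/c2cn(-c3ccccc3)nc2-c2ccccc2)c1N` is not yet measured. It differs from compound 2 by 3-nitrophenyl in place of 4-methoxyphenyl on an aromatic carbon. Among the compounds with values here, no measured pair covers the exchange of 4-methoxyphenyl for 3-nitrophenyl, so the step from compound 1 to compound 2 bears on it only loosely, in that it shows a substituent change on this aromatic carbon can move this assay by a modest amount beyond the scatter. Compound 1, the other compound with a group in the 3-position of the phenyl, sits higher than compound 2. The number for compound 3 is therefore expected to fall between those of compound 2 and compound 1, a step of a 1.9-fold higher number from compound 2 to compound 3 (0.28 log units; within the scatter) being the estimate. Compound 3 is estimated at 95 ug/mL, within 40 ug/mL to 230 ug/mL.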

Compound 3, half-maximal inhibitory concentration: 124 ug/mL
The estimate for compound 3 lay 1.3-fold (0.12 log units) below the measured number, within the range that was stated.
By their numbers in this assay, from the lowest: compound 2; then compounds 3 and 1 (each within the scatter of the next).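

Notes on the aryl position: in this assay, the exchange at this aromatic carbon gives a 2.5-fold higher number from compound 2 to compound 3 (0.39 log units; beyond the scatter), so compound 2 now stands apart from both 3-substituted phenyl compounds rather than from the 3-fluorophenyl compound alone. Nitro in place of fluoro on the phenyl gives a 1.2-fold lower number from compound 1 to compound 3 (0.09 log units; within the scatter), so this exchange does not separate compound 1 from compound 3, and across these three compounds only 4-methoxyphenyl gives a number set apart from the others. Nothing available speaks to the origin of this separation, which remains a description of the numbers alone.

The compounds shown leave open whether the separation of compound 2 goes with the methoxy group itself or with its placement, and a methoxy group placed as the fluoro and nitro groups are in 3-fluorophenyl and 3-nitrophenyl would address that directly. They also leave open how an unsubstituted phenyl, or a phenyl carrying an amine or a carboxylic acid, would stand at this carbon on the shared core.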